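Swapping a Methyl for a Pyridinyl: Solubility in Question

This account rests on a few compounds, and the source may have more. Where it says the series, first, only, none or still open, it means among the compounds named here.

Compound 3 `Cc1nc(C(C)(C)C)nc2nc(N)c(C#N)c(N)c12` holds the higher of the two definite numbers in a physicochemical assay for solubility, in phosphate buffer, with a stated time of 18 h (a higher number here means a more soluble compound, a lower number a less soluble compound), where compound 3 gives 37000 nM. Compound 1 `CC(C)(C)c1ccc2c(N)c(C#N)c(N)nc2n1` gives 14200 nM, a gap that lies beyond the usual scatter. Compound 2 `CC(C)c1ncc2c(N)c(C#N)c(N)nc2n1` has no number at all: its reading is a limit of the assay, > 1000000 nM, which is the limit of > 1000000 nM in this assay, at which 1 of the 3 values shown sits. Compound 4 `CC(C)(C)c1nc(-c2ccncc2)c2c(N)c(C#N)c(N)nc2n1` differs from compound 3 only by pyridin-4-yl in place of methyl on an aromatic carbon. Going by the values given here, no measured pair shows a change of this kind, so nothing here says what it does to solubility. Still, the expected step of a 3.1-fold lower number from compound 3 to compound 4 (0.49 log units; beyond the scatter) is a moderate fall, beyond the scatter. Compound 4 is therefore estimated at 12000 nM, with a likely range from 3000 nM to 50000 nM.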

Compound 4, solubility: 44000 nM
For compound 4 the middle estimate is 3.7-fold (0.56 log units) below the measured one, within the range that was stated.
By their numbers in this assay, from the lowest: compound 1; then compounds 3 and 4 (each within the scatter of the next). At a limit, above all of these: compound 2.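

Putting pyridin-4-yl in place of methyl on this aromatic carbon, next to the ring nitrogen, gives a 1.2-fold higher number from compound 3 to compound 4 (0.08 log units; within the scatter) in this assay. Going by these compounds alone, this is the first measured pair at this position, and it shows that the much larger group leaves the two readings indistinguishable. Nothing measured here bears on why the two readings sit so close. As far as these compounds go, whether an amine or a carboxylic acid on this carbon would also stay within the scatter remains open. So does the effect of a longer chain, such as butyl, in the same place.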